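Swapping trifluoromethyl for fluoro on the aryl sulfone

The compounds below may be only part of what the source reports. "The series", "measured", "known", "first", "only" and "open" are said of these compounds alone.

Of the compounds shown here, two sharing one core have been measured in a functional assay on HeLa cells for agonist activity at 5-hydroxytryptamine receptor 6 (Homo sapiens), read by cAMP accumulation and immunoassay; a higher number here means a larger maximal response, a lower number a smaller maximal response. Compound 1 `O=S(=O)(c1cccc(F)c1)c1cn(C2CCNC2)c2ncccc12` gives 44%. Compound 2 `CN1CCCC(n2cc(S(=O)(=O)c3cccc(C(F)(F)F)c3)c3cccnc32)C1` gives 66%, the higher of the two numbers, and its gap to compound 1 lies beyond the usual scatter. Compound 3 `CN1CCCC(n2cc(S(=O)(=O)c3cccc(F)c3)c3cccnc32)C1` is not yet measured; it differs from compound 2 only in this way: fluoro in place of trifluoromethyl on an aromatic carbon. A downward step of moderate size is expected from compound 2 to compound 3, a number 11 percentage points lower from compound 2 to compound 3 (beyond the scatter), because compound 1, which also carries fluoro, gives 44%. For compound 3 the expected response is 55%, ranging from 40% to 70%.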

Compound 3, largest response reached (Emax), in percent of the reference or control that the assay uses: 75%
Compound 3: middle estimate off by 20 percentage points, on the low side; the measured number lies above the stated range.
By their numbers in this assay, from the lowest: compound 1; then compounds 2 and 3 (each within the scatter of the next).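

In this assay, fluoro in place of trifluoromethyl on the aromatic carbon gives a number 9 percentage points higher from compound 2 to compound 3 (within the scatter), so these two groups cannot be told apart at this position. With fluoro held constant, 1-methylpiperidin-3-yl in place of pyrrolidin-3-yl on the aromatic nitrogen gives a number 31 percentage points higher from compound 1 to compound 3 (beyond the scatter), making that nitrogen substituent the place where a change beyond the scatter is seen. Nothing available explains either step. Still open, from the compounds shown here alone, is whether a methoxy group or an amine on that aromatic carbon would give a similar response, and whether a piperidin-3-yl group without the methyl would match 1-methylpiperidin-3-yl.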